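Adding a Second Fluorine to Compound 1

A few compounds are considered here, and "the series" means these few. Any claim that something is new, unique, unknown or untested is made for them only; others in the source may bear on it.

Measured so far, in a functional assay on BGC-823 cells (Homo sapiens) for inhibition, read by sulforhodamine B assay, with a stated time of 48 h, tested at 10 uM; on this read-out higher numbers stand for more inhibition of growth at the one concentration tested and lower numbers for less inhibition of growth:
Compound 1 `O=C(N/N=C/c1ccccc1O)c1ccc(-c2ccc(F)cc2)o1` gives 74%.
Compound 2 `O=C(N/N=C/c1ccc(O)cc1)c1ccc(-c2ccc(F)cc2)o1` gives 46.3%.

Compound 1 stands highest of these two numbers. Among the compounds with values here, the one measured step, a number 27.7 percentage points lower from compound 1 to compound 2 (beyond the scatter), exchanges the 2-hydroxyphenyl of compound 1 for a 4-hydroxyphenyl on the carbon with a double bond to nitrogen and lowers growth inhibition beyond the scatter.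

Compound 3 `O=C(N/N=C/c1ccccc1O)c1ccc(-c2ccc(F)cc2F)o1` keeps the 2-hydroxyphenyl of compound 1 and differs from it only by fluoro in place of hydrogen on an aromatic carbon, read one bond further out as 4-fluorophenyl to 2,4-difluorophenyl. Within the data shown here, no measured pair touches that ring; the only step available concerns the hydroxyphenyl and does not bear on this change. The expectation therefore rests on compound 1 alone, and compound 3 is expected to land close to it, with a step of a number 2 percentage points lower from compound 1 to compound 3 (within the scatter) that stays within the scatter. The estimate for compound 3 in this assay is 72%, with a range from 55% to 88%.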

Compound 3, percent growth inhibition at one concentration: 79.1%
Estimate against measurement, compound 3: 7.1 percentage points below; low and high end bracket the measured number.
By their numbers in this assay, from the lowest: compound 2; then compounds 1 and 3 (each within the scatter of the next).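

In this assay, within the data shown here, the change from 4-fluorophenyl to 2,4-difluorophenyl gives a number 5.1 percentage points higher from compound 1 to compound 3 (within the scatter), so this is the first sign that the fluorine-bearing ring accepts a fluoro on an aromatic carbon, ortho to a large group, without a readable change in growth inhibition. Among these compounds, this contrasts with the only earlier step, on the other aromatic ring, which gave a number 27.7 percentage points lower from compound 1 to compound 2 (beyond the scatter) and lay beyond the scatter. No measurement shown here explains why the added fluoro leaves growth inhibition within the scatter.

The compounds shown leave open whether a chlorine, a methoxy group or an amine on the same aromatic carbon would also be accepted. They also leave open whether the second fluoro would act the same way alongside the 4-hydroxyphenyl of compound 2.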